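Chloro in place of hydrogen on a bis-benzylidene cyclohexanone

A few compounds are considered here, and "the series" means these few. Any claim that something is new, unique, unknown or untested is made for them only; others in the source may bear on it.

Measured compounds:
compound 1, `O=C1/C(=C/c2ccccc2)CCC/C1=C\c1cccc([N+](=O)[O-])c1`, gives 9440 nM
compound 2, `O=C1/C(=C/c2ccc(F)cc2)CCC/C1=C\c1ccc([N+](=O)[O-])cc1`, gives 26800 nM
compound 3, `O=C1/C(=C/c2ccc(Cl)cc2)CCC/C1=C\c1ccccc1[N+](=O)[O-]`, gives 9380 nM

These three compounds were tested in a functional assay on L1210 cells (Mus musculus) for cytotoxicity, with a stated time of 48 h; on this read-out higher numbers stand for weaker inhibition and lower numbers for stronger inhibition. On these numbers compound 1 sits second highest of three. Its nearest neighbour is compound 3, whose value lies within the usual scatter of compound 1; the furthest is compound 2, whose value stands beyond the scatter above compound 1. Within the data shown here, no single-point step between measured compounds is available, so nothing shows directly how one group exchange moves the read-out.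

Compound 4, `O=C1/C(=C/c2ccc(Cl)cc2)CCC/C1=C\c1cccc([N+](=O)[O-])c1`, has not been measured. It differs from compound 1 by chloro in place of hydrogen on an aromatic carbon; the change sits on an aromatic carbon of a six-membered aromatic ring of carbon only, para to a large group, and one bond further out reads phenyl to 4-chlorophenyl. Compound 3 already carries a 4-chlorophenyl group and gives a number close to compound 1, so the expected step in this assay is small, with no clear direction beyond the scatter. Compound 4 is therefore estimated at 9000 nM, with a range from 4000 nM to 20000 nM, the expected step being a 1.0-fold lower number from compound 1 to compound 4 (0.02 log units; within the scatter).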

Compound 4, half-maximal inhibitory concentration: 9160 nM
The estimate for compound 4 lay 1.0-fold (0.01 log units) below the measured number, within the range that was stated.
By their numbers in this assay, from the lowest: compounds 4, 3 and 1 (each within the scatter of the next); then compound 2.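

In this assay, placing chloro on this aromatic carbon, para to a large group, gives a 1.0-fold lower number from compound 1 to compound 4 (0.01 log units; within the scatter). Among these compounds, this is the first direct reading of a single change, and it shows that, on the core of compound 1, the phenyl and 4-chlorophenyl forms cannot be told apart in this test, so this position accepts the extra chlorine atom with no detectable shift in either direction. No measurement is available here that could explain this flat result.

One exchange at one position cannot show whether this position is indifferent to its substituent in general, and a methoxy group, an amine or a carboxylic acid in the same place might behave quite differently from chloro. Going by these compounds, compound 2, which carries fluoro, differs from compound 4 in more than one place, so its higher number cannot be assigned to either difference, and what the halogen alone contributes at this position remains open beyond the chloro result.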